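Swapping the benzyl substituents on a xanthine-like core

The source may hold more compounds than are shown below. What is called first, only, known or untested is meant among the compounds shown, and "the series" means these compounds.

Compound 1 `CCCn1c(=O)c2nc(-c3cnn(Cc4cc(Cl)ccc4Cl)c3)[nH]c2n(CCC)c1=O` is the compound to beat here. Within the data shown here, in an in vitro assay on HEK293 cells for displacement of a labelled ligand from adenosine receptor A2b (Homo sapiens) (a lower number here means a stronger inhibitor, a higher number a weaker inhibitor), compound 1 gives 29 nM, the lowest of the three numbers measured so far. Compound 3 `CCCn1c(=O)c2nc(-c3cnn(Cc4ccc(OC)c(C(F)(F)F)c4)c3)[nH]c2n(CCC)c1=O` gives 410 nM, and compound 2 `CCCn1c(=O)c2nc(-c3cc(C)nn3C)[nH]c2n(CCC)c1=O` gives 3700 nM, both well beyond the scatter from compound 1.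

Compound 4 `CCCn1c(=O)c2nc(-c3cnn(Cc4ccccc4C)c3)[nH]c2n(CCC)c1=O` has not been measured. It differs from compound 1 in one place: 2-methylphenyl in place of 2,5-dichlorophenyl on a saturated chain carbon bound to an aromatic nitrogen. Among the measured compounds shown here, no measured pair shows this exact change, so the expected step from compound 1 to compound 4 is an estimate, a 3.1-fold higher number from compound 1 to compound 4 (0.49 log units; beyond the scatter), with the number expected to rise somewhat since compound 3 shows that another benzyl substituent pattern gives 410 nM. Compound 4 is therefore expected to give about 90 nM, probably between 25 nM and 320 nM.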

Compound 4, inhibition constant: 33 nM
For compound 4 the middle estimate is 2.7-fold (0.44 log units) above the measured one, and the stated range covers the measured number.
By their numbers in this assay, from the lowest: compounds 1 and 4 (each within the scatter of the next); then compound 3; then compound 2.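

In this assay, 2-methylphenyl in place of 2,5-dichlorophenyl on this saturated chain carbon gives a 1.1-fold higher number from compound 1 to compound 4 (0.06 log units; within the scatter), so the two compounds cannot be told apart. Compound 4 carries no chlorine, which shows that chlorine on this ring is not needed for a number in this range. Nothing available here explains why these two groups match.

Still open, going by these compounds, is how a plain benzyl group, with no substituent on its ring, would fare in this assay. The same holds for a benzyl group carrying an amine or a carboxylic acid.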